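The source may hold more compounds than are shown below. What is called first, only, known or untested is meant among the compounds shown, and "the series" means these compounds.

Measured so far in a functional assay on U-87MG ATCC cells (Homo sapiens) for cytotoxicity, read by MTT assay, with a stated time of 72 h; a higher number here means a weaker inhibitor, a lower number a stronger inhibitor:
compound 1 `COc1cc2c(Oc3ccc(NC(=O)c4nnn(-c5ccccc5C)c4C)cc3F)ccnc2cc1OCCCN1CCCC1` gives 1600 nM;
compound 2 `COc1cc2c(Oc3ccc(NC(=O)c4nnn(-c5ccccc5C(F)(F)F)c4C(F)(F)F)cc3F)ccnc2cc1OCCCN1CCCC1` gives 1180 nM;
compound 3 `COc1cc2c(Oc3ccc(NC(=O)c4nnn(-c5ccccc5C)c4C)cc3F)ccnc2cc1OCCCN1CCCCC1` gives 2370 nM.

Compound 3 has the highest of these three numbers, but its separation from compound 1 is the step of a 1.5-fold higher number from compound 1 to compound 3 (0.17 log units; within the scatter), and compound 2 sits within the scatter of compound 3 as well, so the three are not ordered by this assay. Compound 4 `COc1cc2c(Oc3ccc(NC(=O)c4nnn(-c5ccccc5C(F)(F)F)c4C)cc3F)ccnc2cc1OCCCN1CCCCC1` differs from compound 3 by trifluoromethyl in place of methyl on an aromatic carbon. Going by the values given here, no single measured step covers this change; compound 1 and compound 2 differ at two places at once, and their values fall within the scatter of each other. On that basis the step from compound 3 to compound 4 is expected to stay within the scatter, a 1.2-fold lower number from compound 3 to compound 4 (0.07 log units; within the scatter). Compound 4 is therefore estimated at 2000 nM, with a range from 900 nM to 4500 nM.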

Compound 4, half-maximal inhibitory concentration: 1150 nM
Compound 4: middle estimate off by 1.7-fold (0.24 log units), on the high side; the measured number falls inside the stated range.
By their numbers in this assay, from the lowest: compounds 4, 2, 1 and 3 (each within the scatter of the next, the first and the last beyond it).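

In this assay, going by these compounds alone, trifluoromethyl in place of methyl on an aromatic carbon, ortho to a large group, gives a 2.1-fold lower number from compound 3 to compound 4 (0.31 log units; beyond the scatter) and is the first single-place change to pass the scatter. Within the data shown here, the only earlier single-place step, a 1.5-fold higher number from compound 1 to compound 3 (0.17 log units; within the scatter), stayed within it, so this aromatic carbon is the one place so far where a change can be read. No measurement shown bears on the cause of this step.

As far as these compounds go, whether the same change gives a similar step with pyrrolidin-1-yl on the chain remains open. So does the effect of a chlorine or a methoxy group on this aromatic carbon.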